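A few compounds are considered here, and "the series" means these few. Any claim that something is new, unique, unknown or untested is made for them only; others in the source may bear on it.

Measured so far in an assay on cells for displacement of a labelled ligand from transmembrane domain-containing protein TMIGD3 (Homo sapiens), read by scintillation counting, with a stated time of 120 min; a higher number here means a weaker inhibitor, a lower number a stronger inhibitor:
compound 1 `O=C(Nc1nccn2cc(-c3ccccc3)nc12)c1ccccc1` gives 52 nM
compound 2 `Cc1ccc(C(=O)Nc2nc(-c3ccccc3)cn3cc(-c4ccccc4)nc23)cc1` gives 223 nM

Compound 2 holds the highest of the two numbers in this assay; its nearest neighbour is compound 1, whose number is lower by a gap that lies beyond the scatter. Compound 3 `O=C(Nc1nc(-c2ccccc2)cn2cc(-c3ccccc3)nc12)c1cccnc1` has not yet been measured in this assay. The change made is pyridin-3-yl in place of 4-methylphenyl on a carbonyl carbon. Among the measured compounds shown here, no measured pair shows this change, so no step can be read off from the numbers so far. The estimated step of a 1.3-fold higher number from compound 2 to compound 3 (0.13 log units; within the scatter) is expected to be small, in either direction, or none beyond the scatter. Compound 3 is estimated at 300 nM, within a range of 100 nM to 900 nM.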

Compound 3, inhibition constant: 54 nM
Compound 3: middle estimate off by 5.6-fold (0.74 log units), on the high side; measured number below the stated range.
By their numbers in this assay, from the lowest: compounds 1 and 3 (each within the scatter of the next); then compound 2.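

In this assay, among the compounds shown here, pyridin-3-yl in place of 4-methylphenyl on the carbonyl carbon gives a 4.1-fold lower number from compound 2 to compound 3 (0.62 log units; beyond the scatter) and is the first step read at this position. With the rest of the structure held fixed, the group on this carbonyl carbon clearly moves the number. The change both removes the methyl and brings in a ring nitrogen, and these two parts cannot be separated here; no measured evidence accounts for the step. Still open, on these data alone, is whether pyridin-4-yl or pyridin-2-yl matches pyridin-3-yl here. Also open, as far as these compounds go, is how an amine or a carboxylic acid on this ring would read.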